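This account rests on a few compounds, and the source may have more. Where it says the series, first, only, none or still open, it means among the compounds named here.

Of the compounds shown here, two from this series have been measured in a functional assay on DU-145 cells (Homo sapiens) for cytotoxicity, in the presence of a further agent that is not named here; on this read-out lower numbers stand for stronger inhibition and higher numbers for weaker inhibition. Compound 1, with structure `Clc1ccc(-c2cc(-c3cccnc3)nc(-c3cccs3)c2)o1`, gives 13000 nM in this assay. Compound 2, with structure `Cc1ccccc1-c1cc(-c2ccc(Cl)o2)cc(-c2ccsc2)n1`, gives 24800 nM in this assay. The two numbers sit within the usual scatter of each other, so neither compound can be called the more potent; both show only weak cytotoxicity on these cells.

Compound 3, with structure `Clc1ccc(-c2cc(-c3cccs3)nc(-c3ccccc3Cl)c2)o1`, has not yet been measured. It is built from compound 1 by the change (2-chlorophenyl in place of pyridin-3-yl on an aromatic carbon). Going by the values given here, no pair of measured compounds that differ in exactly one place is available here, so the size of this kind of step cannot be read from data; the only guide is that both measured compounds lie in the same weak range. On that basis a change of little more than the scatter is expected in this assay, with no clear direction, and the step from compound 1 to compound 3 is estimated as a 1.2-fold higher number from compound 1 to compound 3 (0.06 log units; within the scatter). Compound 3 is thus expected to give about 15000 nM in this assay, most likely between 4000 nM and 50000 nM.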

Compound 3, half-maximal inhibitory concentration: 16800 nM
The estimate for compound 3 lay 1.1-fold (0.05 log units) below the measured number; the range from low to high includes it.
By their numbers in this assay, from the lowest: compounds 1, 3 and 2 (each within the scatter of the next).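

In this assay, going by these compounds alone, putting 2-chlorophenyl in place of pyridin-3-yl on the aromatic carbon next to the ring nitrogen gives a 1.3-fold higher number from compound 1 to compound 3 (0.11 log units; within the scatter), and this is the first step that can be read between two compounds differing in one place. The swap is not a small one on paper: the ring nitrogen and the hydrogen-bond acceptor of pyridin-3-yl leave, and a carbon-only ring carrying a chlorine enters, yet the two numbers stay within the scatter, so this position tolerates this particular exchange without a measurable difference on these cells. No measurement is at hand that would explain this outcome.

Still open, from the compounds shown here alone, is whether any group at this position can move the number beyond the scatter, for instance a ring bearing an amine or a carboxylic acid, or a small methoxy group in place of the chlorine on the phenyl ring. Also open is how much the 5-chlorofuran-2-yl and thiophen-2-yl groups contribute, since no single-place step at either of those positions is available among these compounds.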